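A few compounds are considered here, and "the series" means these few. Any claim that something is new, unique, unknown or untested is made for them only; others in the source may bear on it.

Three measured compounds share one core and are compared in a functional assay on MIA PaCa-2 cells (Homo sapiens) for inhibition, read by MTT assay, with a stated time of 7 days; on this read-out higher numbers stand for weaker inhibition and lower numbers for stronger inhibition. Compound 1 `O=C([C@@H]1CCCN(S(=O)(=O)c2ccc(S(=O)(=O)C3CCC3)cc2)C1)N1CCC(F)(F)CC1` gives 9 nM in this assay, the lowest of the three numbers. Among the measured compounds shown here, compound 3 `O=C([C@@H]1CCCN(S(=O)(=O)c2ccc(S(=O)(=O)N3CC[C@@H](O)C3)cc2)C1)N1CCC(F)(F)CC1` gives 210 nM, and the single one-place step between them, a 23-fold higher number from compound 1 to compound 3 (1.37 log units; beyond the scatter), is a large move toward weaker inhibition. Compound 2 `CCN(CC)S(=O)(=O)c1ccc(S(=O)(=O)N2CCC[C@@H](C(=O)N3CCS(=O)(=O)CC3)C2)cc1` gives 900 nM, the highest number of the three: it sits well beyond the scatter from compound 3 and very far from compound 1, so it is the weakest inhibitor here.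

The next compound, compound 4 `CCN(CC)S(=O)(=O)c1ccc(S(=O)(=O)N2CCC[C@@H](C(=O)N3CCC(OC)CC3)C2)cc1`, keeps everything of compound 2 except the group on the carbonyl carbon: 4-methoxypiperidin-1-yl in place of 1,1-dioxothiomorpholin-4-yl on a carbonyl carbon.

For the measured compounds named here, no measured step changes the group on the carbonyl carbon on its own. Going by the values given here, the only measured step, a 23-fold higher number from compound 1 to compound 3 (1.37 log units; beyond the scatter), alters the group on the sulfonyl sulfur instead, and compound 1 differs from compound 2 in two places at once, so their values cannot be split into separate contributions. The expectation for compound 4 therefore rests weakly on the data: a modest move toward stronger inhibition is expected, as a 2.6-fold lower number from compound 2 to compound 4 (0.41 log units; beyond the scatter), with wide uncertainty. Compound 4 is estimated at 350 nM, within a range from 80 nM to 1500 nM.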

Compound 4, half-maximal inhibitory concentration: 140 nM
Estimate against measurement, compound 4: 2.5-fold (0.40 log units) above; low and high end bracket the measured number.
By their numbers in this assay, from the lowest: compound 1; then compounds 4 and 3 (each within the scatter of the next); then compound 2.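

Among the compounds shown here, until now, no measured step isolated the group on the carbonyl carbon, and the step from 1,1-dioxothiomorpholin-4-yl to 4-methoxypiperidin-1-yl, a 6.4-fold lower number from compound 2 to compound 4 (0.81 log units; beyond the scatter), shows that this position affects the result in this assay when the rest of the molecule stays fixed. The change is more subtle than a change in the size of the group: both groups have 8 heavy atoms and a six-membered non-aromatic ring, but the entering group has no sulfur or double bonds outside aromatic rings, and it has 1 hydrogen-bond acceptor rather than 2. No supporting measurement explains why this exchange gives a lower number.

The shown compounds do not reveal whether removing the 1,1-dioxothiomorpholin-4-yl group or introducing the methoxy group matters more, a question that a plain piperidin-1-yl or a morpholin-4-yl group on the carbonyl carbon could help separate. As far as these compounds go, it also remains open whether a 4-hydroxypiperidin-1-yl or 4-aminopiperidin-1-yl group would fit the same trend, and whether this exchange would have a similar effect with the other sulfonyl groups seen in compound 1 and compound 3.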